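This account rests on a few compounds, and the source may have more. Where it says the series, first, only, none or still open, it means among the compounds named here.

Working notes on the series.

The shared core carries a biaryl sulfonamide, and the three measured compounds differ only in the ring at its far end. Compound 1 `COc1ccc(N2C[C@@H](C)N[C@@H](C)C2)cc1NS(=O)(=O)c1ccc(-c2cc(Cl)ccc2F)cc1` reaches 1 in a functional assay for agonist activity at growth hormone secretagogue receptor type 1 (Homo sapiens), read by FLIPR; a lower number here means a smaller maximal response, a higher number a larger maximal response. Compound 2 `COc1ccc(N2C[C@@H](C)N[C@@H](C)C2)cc1NS(=O)(=O)c1ccc(-c2cnco2)s1` gives 0.9 in this assay. Compound 3 `COc1ccc(N2C[C@@H](C)N[C@@H](C)C2)cc1NS(=O)(=O)c1ccc(-c2ccncc2)cc1` gives 0.7 in this assay, the lowest of the three numbers; compound 2 lies above it beyond the scatter and compound 1 further still. Within the data shown here, the one single-point step in hand is a number 0.30 lower from compound 1 to compound 3 (beyond the scatter), so the ring on that aromatic carbon can move the maximal response by a modest amount.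

Compound 4 `COc1ccc(N2C[C@@H](C)N[C@@H](C)C2)cc1NS(=O)(=O)c1ccc(-n2cccn2)cc1` is the next step from compound 3: 1H-pyrazol-1-yl in place of pyridin-4-yl on an aromatic carbon. The group enters on an aromatic carbon of a six-membered aromatic ring of carbon only, para to a large group. Among the measured compounds shown here, no measured pair shows this exact exchange. Compound 2, which also ends in a five-membered aromatic ring with two hetero atoms, sits higher than compound 3, but it differs from compound 3 in more than one place, so its value is only a hint. The step a number 0.30 lower from compound 1 to compound 3 (beyond the scatter) shows the read-out can fall by a modest amount with a ring swap; a return toward the values of compound 1 and compound 2 is plausible but not assured. For compound 4 the expected step is a number 0.10 higher from compound 3 to compound 4 (within the scatter), a small rise that may stay within the scatter. Compound 4 is thus estimated at 0.8, between 0.6 and 1.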

Compound 4, intrinsic activity: the largest response reached, as a fraction of the reference agonist's: 0.8
The estimate for compound 4 equals the measured number at the digits printed; measured number inside the range.
By their numbers in this assay, from the lowest: compounds 3, 4, 2 and 1 (each within the scatter of the next, the first and the last beyond it).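

In this assay, the step a number 0.10 higher from compound 3 to compound 4 (within the scatter) shows that 1H-pyrazol-1-yl and pyridin-4-yl are not told apart at this position, even though one is a five-membered aromatic ring with 2 hetero atoms and the other a six-membered aromatic ring with 1 hetero atom. The step a number 0.20 lower from compound 1 to compound 4 (beyond the scatter) lies beyond the scatter, so compound 4, like compound 3, stands apart from the 5-chloro-2-fluorophenyl group of compound 1, and this now holds for two different nitrogen-containing rings on this aromatic carbon rather than one. Nothing in hand gives a reason for either step.

The compounds shown do not separate the contribution of the ring nitrogens from that of the chloro and fluoro substituents, and an unsubstituted phenyl ring on the same carbon would bear directly on that question. Also open, from the compounds shown here alone, is whether the maximal response on this carbon holds with a group of another kind, such as a carboxylic acid, a primary amine or a longer alkyl chain, in place of an aromatic ring.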